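Series notes: halogen placement on the pendant phenyl

The compounds below may be only part of what the source reports. "The series", "measured", "known", "first", "only" and "open" are said of these compounds alone.

The shared core, seen in compound 1 `CCCS(=O)(=O)Nc1ccc(F)c(C(=O)c2n[nH]c3ncc(-c4ccccc4Cl)cc23)c1F` and compound 2 `CCCS(=O)(=O)Nc1ccc(F)c(C(=O)c2n[nH]c3ncc(-c4cccc(Cl)c4)cc23)c1F`, carries a chlorophenyl on an aromatic carbon of the fused ring, two atoms from the ring nitrogen. In an assay for binding affinity to dual specificity mitogen-activated protein kinase kinase 4 (Homo sapiens), read by KINOMEscan, tested at 100 nM (a lower number here means a stronger effect, a higher number a weaker effect of the compound at the concentration tested), compound 1 gives 9.3% and compound 2 gives 40%. Within the data shown here, compound 2 stands highest of the two numbers measured so far; its nearest neighbour is compound 1, and the single measured step, a number 30.7 percentage points higher from compound 1 to compound 2 (beyond the scatter), is the only comparison available.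

Compound 3 `CCCS(=O)(=O)Nc1ccc(F)c(C(=O)c2n[nH]c3ncc(-c4ccccc4F)cc23)c1F` differs from compound 2 by 2-fluorophenyl in place of 3-chlorophenyl on an aromatic carbon. Compound 3 thus shares with compound 1 the halogen placement of 2-chlorophenyl, but with fluorine in place of chlorine. The step of a number 30.7 percentage points higher from compound 1 to compound 2 (beyond the scatter) bears directly on the placement part and was large; nothing measured bears on chlorine against fluorine. A downward step in this assay is therefore expected, broadly of the size already seen, with the halogen swap leaving the exact size open. Compound 3 is expected to give 15%, between 4% and 35%, which means an estimated step of a number 25 percentage points lower from compound 2 to compound 3 (beyond the scatter).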

Compound 3, a percentage reported as activity, at one concentration (the size of the read-out at that concentration, not a potency): 2%
Beside the measured number, compound 3's estimate is 13 percentage points above it, and the stated range ends above it.
By their numbers in this assay, from the lowest: compounds 3 and 1 (each within the scatter of the next); then compound 2.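

In this assay the change to 2-fluorophenyl gives a number 38 percentage points lower from compound 2 to compound 3 (beyond the scatter) and so brings the number back down to the level of compound 1, which shows that the low reading at this position is not confined to the 2-chlorophenyl group. Fluoro in place of chloro gives a number 7.3 percentage points lower from compound 1 to compound 3 (within the scatter) and is the only comparison here that isolates the halogen, so chlorine and fluorine cannot be told apart when placed as in the 2-chlorophenyl and 2-fluorophenyl groups. Nothing at hand explains why these two compounds read lower than compound 2.

The compounds shown leave open whether a halogen is needed on this phenyl at all, since an unsubstituted phenyl, a 2-methylphenyl or a 2-methoxyphenyl could tell whether the placement alone carries the low number. A 3-fluorophenyl group would also show whether the higher number of compound 2 follows the placement with fluorine as well, which would separate placement from halogen in the large step between compound 2 and compound 3.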